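Removing Two Fluorines from a Sphingosine Receptor Agonist

The compounds below may be only part of what the source reports. "The series", "measured", "known", "first", "only" and "open" are said of these compounds alone.

The measured compounds:
- Compound 1, `C/N=C1\S/C(=C\c2cc(C)n(-c3ccc(F)cc3)c2C)C(=O)N1C`: 652 nM
- Compound 2, `C/N=C1\S/C(=C\c2cc(C)n(Cc3ccc(F)cc3F)c2C)C(=O)N1C`: 37 nM

In a functional assay for agonist activity at sphingosine 1-phosphate receptor 5 (Homo sapiens) (on this read-out higher numbers stand for an effect only at larger amounts of compound and lower numbers for an effect already at smaller amounts), compound 1 gives 652 nM, whereas compound 2 gives 37 nM. Of the two numbers, compound 2 holds the lower one, and the gap to compound 1 lies well beyond the usual scatter. For the measured compounds named here, the two compounds differ in more than one place, so their values show only that compound 2 acts at a smaller amount than compound 1; no single structural cause can be read from them.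

Compound 3, `C/N=C1\S/C(=C\c2cc(C)n(Cc3ccccc3)c2C)C(=O)N1C`, has not yet been measured in this assay. It differs from compound 2 in one place: phenyl in place of 2,4-difluorophenyl on a saturated chain carbon bound to an aromatic nitrogen. Going by the values given here, no measured pair in this set isolates such a change, so the size of the step is open. A modest shift, within or just beyond the scatter, is expected rather than a large one. Compound 3 is therefore estimated to give 70 nM, with a plausible range from 20 nM to 250 nM, an expected step of a 1.9-fold higher number from compound 2 to compound 3 (0.28 log units; within the scatter).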

Compound 3, half-maximal effective concentration: 144 nM
Compound 3: middle estimate off by 2.1-fold (0.31 log units), on the low side; measured number inside the range.
By their numbers in this assay, from the lowest: compound 2; then compound 3; then compound 1.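

In this assay, for the compounds shown here, phenyl in place of 2,4-difluorophenyl on a saturated chain carbon bound to an aromatic nitrogen gives a 3.9-fold higher number from compound 2 to compound 3 (0.59 log units; beyond the scatter) and so isolates, for the first time here, what the two fluorines together are worth on this group: the step lies beyond the scatter, so they are not a silent decoration. Benzyl in place of 4-fluorophenyl on an aromatic nitrogen gives a 4.5-fold lower number from compound 1 to compound 3 (0.66 log units; beyond the scatter) as well, which shows that the unfluorinated benzyl group already acts at a smaller amount than the 4-fluorophenyl group. The wide gap between compound 1 and compound 2 therefore divides into two steps, each beyond the scatter, with neither accounting for all of it, and nothing at hand explains either step.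

Still open, as far as these compounds go, is whether a single fluorine would carry part of the first step, or whether chlorine, a methoxy group or a trifluoromethyl group on the phenyl ring would serve in the same way. Equally open, from the compounds shown here alone, is how a longer chain, such as phenethyl on the aromatic nitrogen, would compare with benzyl.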